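This account rests on a few compounds, and the source may have more. Where it says the series, first, only, none or still open, it means among the compounds named here.

Measured in a functional assay on HT-29 cells (Homo sapiens) for cytotoxicity, read by MTT assay, with a stated time of 72 h; on this read-out lower numbers stand for stronger inhibition and higher numbers for weaker inhibition:
compound 1 `O=C1N/C(=N/c2csc(-c3ccc(Cl)cc3)c2)S/C1=C\c1ccc(Br)cc1` gives 2000 nM;
compound 2 `O=C1N/C(=N/c2csc(-c3ccc(Cl)cc3)c2)S/C1=C\c1ccc2ccccc2c1` gives 3700 nM;
compound 3 `CCCCCC/C=C1\S/C(=N\c2csc(-c3ccc(Cl)cc3)c2)NC1=O` gives 33500 nM.

Compound 3 has the highest number of the three, and since a 17-fold higher number from compound 1 to compound 3 (1.22 log units; beyond the scatter) and a 9.1-fold higher number from compound 2 to compound 3 (0.96 log units; beyond the scatter) are both beyond the scatter, it is the weakest of the set. Compound 4 `O=C1N/C(=N/c2csc(-c3ccc(Cl)cc3)c2)S/C1=C\c1ccccn1` differs from it in one place: pyridin-2-yl in place of hexyl on a double-bonded chain carbon bound to a double-bonded ring carbon. Among the measured compounds shown here, the steps that bear on this change are the two in which an aromatic ring gave way to the hexyl chain, a 17-fold higher number from compound 1 to compound 3 (1.22 log units; beyond the scatter) and a 9.1-fold higher number from compound 2 to compound 3 (0.96 log units; beyond the scatter); read in the opposite direction, a ring in place of the chain went with the lower numbers. Compound 4 is therefore expected to give a clearly lower number in this assay, an expected step of an 8.4-fold lower number from compound 3 to compound 4 (0.92 log units; beyond the scatter). The estimate for compound 4 is 4000 nM, with a range from 1500 nM to 12000 nM.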

Compound 4, half-maximal inhibitory concentration: 11500 nM
Compound 4: the middle estimate sits 2.9-fold (0.46 log units) below what was measured, and the stated range covers the measured number.
By their numbers in this assay, from the lowest: compounds 1 and 2 (each within the scatter of the next); then compound 4; then compound 3.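

Pyridin-2-yl in place of hexyl gives a 2.9-fold lower number from compound 3 to compound 4 (0.46 log units; beyond the scatter) in this assay and so extends the link between a ring and a lower number to a ring holding a nitrogen. Yet this ring does less well than the other two, with a 3.1-fold higher number from compound 2 to compound 4 (0.49 log units; beyond the scatter) on replacing naphthalen-2-yl and a 5.8-fold higher number from compound 1 to compound 4 (0.76 log units; beyond the scatter) on replacing 4-bromophenyl, so which ring stands at this place matters, not only whether one is there. Nothing available explains these gaps.

Still open, as far as these compounds go, is where a plain phenyl group would fall, which could help separate the part played by the ring nitrogen from that of the bromine.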